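This account rests on a few compounds, and the source may have more. Where it says the series, first, only, none or still open, it means among the compounds named here.

Compounds measured so far in a functional assay on HL-60 cells (Homo sapiens) for cytotoxicity, read by MTT assay, with a stated time of 24 h; on this read-out lower numbers stand for stronger inhibition and higher numbers for weaker inhibition

- compound 1 `BrCCCCCCOc1c(Br)cc(Br)cc1Oc1ccc(Br)cc1Br` gives 37.8 ug/mL
- compound 2 `CCOC(=O)C(C)Oc1c(Br)cc(Br)cc1Oc1ccc(Br)cc1Br` gives 35.7 ug/mL
- compound 3 `BrCCCCCOc1c(Br)cc(Br)cc1Oc1ccc(Br)cc1Br` gives 25.7 ug/mL

At 25.7 ug/mL compound 3 lies within the scatter of both other compounds, so the numbers do not rank them. Compound 4 `BrCCOc1c(Br)cc(Br)cc1Oc1ccc(Br)cc1Br` is the next to be tested, with 2-bromoethyl where compound 3 has 5-bromopentyl (bromo in place of 3-bromopropyl on a saturated chain carbon, two bonds along the chain from an oxygen on an aromatic ring). For the measured compounds named here, two measured steps bear on this. Changing 6-bromohexyl to 5-bromopentyl gave a 1.5-fold lower number from compound 1 to compound 3 (0.17 log units; within the scatter), and replacing 1-(ethoxycarbonyl)ethyl with 5-bromopentyl gave a 1.4-fold lower number from compound 2 to compound 3 (0.14 log units; within the scatter). Going by the values given here, neither exceeds the scatter, though no measured compound has a chain as short as 2-bromoethyl. The expected result is therefore no shift beyond the scatter, a 1.0-fold lower number from compound 3 to compound 4 (0.01 log units; within the scatter), in this assay. For compound 4 the estimated value is 25 ug/mL, within an expected range of 12 ug/mL to 50 ug/mL, and the measurement will test this.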

Compound 4, half-maximal inhibitory concentration: 26.2 ug/mL
Compound 4: the middle estimate sits 1.0-fold (0.02 log units) below what was measured; the range from low to high includes it.
By their numbers in this assay, from the lowest: compounds 3, 4, 2 and 1 (each within the scatter of the next).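

In this assay, for the compounds shown here, the swap of 5-bromopentyl for 2-bromoethyl stays within the scatter (a 1.0-fold higher number from compound 3 to compound 4 (0.01 log units; within the scatter)), and this is the first sign that a much shorter bromo chain on this oxygen gives a number like those of the longer chains. The comparisons with the other two compounds agree (a 1.4-fold lower number from compound 1 to compound 4 (0.16 log units; within the scatter); a 1.4-fold lower number from compound 2 to compound 4 (0.13 log units; within the scatter)), so these four side chains cannot be ranked. No supporting data explain this flat result. On these data alone, whether an amine or a carboxylic acid in place of the chain's bromine would move the number beyond the scatter remains open.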